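The compounds below may be only part of what the source reports. "The series", "measured", "known", "first", "only" and "open" are said of these compounds alone.

Compound 1 `COc1cc2nccc(Oc3ccc(Nc4nn(C)cc4C(=O)NC4CCCCC4)cc3)c2cc1C(N)=O`: 4800 nM
Compound 2 `COc1cc2nccc(Oc3ccc(Nc4nn(C)cc4C(=O)N4CCCCC4)cc3)c2cc1C(N)=O`: 5650 nM
Compound 3 `COc1cc2nccc(Oc3ccc(Nc4nn(C)cc4C(=O)N4CCCC5CCCCC54)cc3)c2cc1C(N)=O`: 4330 nM

These values come from a functional assay on BaF3 cells (Mus musculus) for antiproliferative activity, read by CCK-8 assay and cell counting, with a stated time of 76 h; on this read-out higher numbers stand for weaker inhibition and lower numbers for stronger inhibition. Compound 1 does not stand apart from the other two compounds. The data show a 1.2-fold higher number from compound 1 to compound 2 (0.07 log units; within the scatter) and a 1.1-fold lower number from compound 1 to compound 3 (0.04 log units; within the scatter), so no ranking can be drawn among these compounds.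

The compound still to be measured is compound 4 `COc1cc2nccc(Oc3ccc(Nc4nn(C)cc4C(=O)NCC(C)C)cc3)c2cc1C(N)=O`. It keeps the core of compound 1 and differs only in isobutyl in place of cyclohexyl on an amide-type nitrogen.

For the measured compounds named here, no measured step makes this exact change. The closest evidence comes from the two steps from compound 1 above, which also alter the group on the carbonyl carbon, and from a 1.3-fold lower number from compound 2 to compound 3 (0.12 log units; within the scatter). All three steps are small, even though the groups exchanged differ in size. However, each of the measured compounds carries a ring in this part of the molecule, while isobutyl has none, so compound 4 moves beyond the tested groups and the range must stay wide.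

No change beyond the scatter is therefore expected in this assay. The expected step is a 1.1-fold higher number from compound 1 to compound 4 (0.03 log units; within the scatter). Compound 4 is estimated at 5200 nM, with an expected range of 2400 nM to 11000 nM.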

Compound 4, half-maximal inhibitory concentration: > 10000 nM
Compound 4 was reported as a limit; the forecaster's own chance of this, stated with the estimate: 10%; at least 1.9-fold (0.28 log units) between middle value and limit.
By their numbers in this assay, from the lowest: compounds 3, 1 and 2 (each within the scatter of the next). At a limit, above all of these: compound 4.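

In this assay compound 4 is reported only as a limit of the assay, not as a number: the limit of > 10000 nM in this assay, at which 1 of the 4 values shown sits. For the compounds shown here, this position is therefore not as tolerant as the earlier compounds suggested: compounds 1, 2 and 3, which all carry a ring in this part of the molecule, lie within the scatter of one another, whereas the open-chain isobutyl group gives an at least 2.0-fold higher number from compound 1 to compound 4 (0.31 log units; beyond the scatter) and also an at least 2.3-fold higher number from compound 3 to compound 4 (0.36 log units; beyond the scatter). Compound 2 is the exception, because the floor of its step, an at least 1.7-fold higher number from compound 2 to compound 4 (0.24 log units; that floor lies within the scatter), does not by itself show a real difference.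

How far compound 4 lies past its limit remains unknown, and with isobutyl as the only open-chain group, the compounds shown cannot separate the loss of the ring from the drop in heavy atoms from cyclohexyl to isobutyl. A cyclopropylmethyl group on the same amide-type nitrogen, which keeps a ring, and a longer chain such as n-hexyl, which has none, would help to tell these two apart.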